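Amide variation on the shared core: notes toward compound 3

A few compounds are considered here, and "the series" means these few. Any claim that something is new, unique, unknown or untested is made for them only; others in the source may bear on it.

compound 1 `CC(=O)N(C)c1ccc2[nH]c(-c3n[nH]c4ccccc34)cc2n1`: > 50000 nM
compound 2 `CN(C(=O)CCc1ccccc1)c1ccc2[nH]c(-c3n[nH]c4ccccc34)cc2n1`: 18100 nM

In a functional assay on A549 cells (Homo sapiens) for antiproliferative activity, read by MTT assay, with a stated time of 72 h (on this read-out higher numbers stand for weaker inhibition and lower numbers for stronger inhibition), compound 1 gives only a limit, > 50000 nM. In this assay, for the measured compounds named here, compound 2 gives 18100 nM, the only true number among the two values shown. The value of compound 1 is a limit (the limit of > 50000 nM in this assay, at which 1 of the 2 values shown sits). Going by the values given here, the single measured step, an at least 2.7-fold lower number from compound 1 to compound 2 (0.44 log units; beyond the scatter), lengthened the chain on the carbonyl. Compound 3 `CN(C(=O)c1ccc(F)cc1)c1ccc2[nH]c(-c3n[nH]c4ccccc34)cc2n1` differs from compound 2 by 4-fluorophenyl in place of phenethyl on a carbonyl carbon. Among the compounds with values here, no measured step exchanges a chain for an aryl group on the carbonyl, so the direction is open; a weaker number than compound 2, toward the limit, is as plausible as an equal one. Compound 3 is expected at 28000 nM, with a range from 8000 nM to 60000 nM. This estimate means an expected step of a 1.5-fold higher number from compound 2 to compound 3 (0.19 log units; within the scatter).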

Compound 3, half-maximal inhibitory concentration: 9650 nM
Beside the measured number, compound 3's estimate is 2.9-fold (0.46 log units) above it; the range from low to high includes it.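

On the carbonyl carbon, 4-fluorophenyl in place of phenethyl gives a 1.9-fold lower number from compound 2 to compound 3 (0.27 log units; within the scatter) in this assay, so an aryl group directly on the carbonyl and the phenethyl chain cannot be told apart here. 4-Fluorophenyl in place of methyl gives an at least 5.1-fold lower number from compound 1 to compound 3 (0.71 log units; beyond the scatter), so compound 3, like compound 2, separates from the methyl amide. The value of compound 1 is a limit: the limit of > 50000 nM in this assay, at which 1 of the 3 values shown sits.

Whether the fluorine contributes remains open, since plain phenyl is not among the compounds shown. Also open, from the compounds shown here alone, is how an amine or a carboxylic acid on the aryl ring, or a longer chain on the carbonyl, would read.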